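Methoxycarbonyl in place of methyl: what to expect

This account rests on a few compounds, and the source may have more. Where it says the series, first, only, none or still open, it means among the compounds named here.

Values measured in a functional assay on HL-60 cells (Homo sapiens) for cytotoxicity, read by CCK-8 assay, with a stated time of 24 h; on this read-out higher numbers stand for weaker inhibition and lower numbers for stronger inhibition:
compound 1 (`C=CC(=O)N1C(=O)CC(c2ccc(C)cc2)Sc2ccccc21`): 94400 nM
compound 2 (`C=CC(=O)N1C(=O)CC(c2ccc(Br)cc2)Sc2ccccc21`): 126000 nM
compound 3 (`C=CC(=O)N1C(=O)CC(c2ccccc2C(F)(F)F)Sc2ccccc21`): 96400 nM

These three compounds share one core and differ in the group carried on an aromatic ring. Compound 1 gives 94400 nM and sits so close to compound 2 and compound 3 that no ranking can be drawn from this assay at this stage.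

The open question is compound 4 (`C=CC(=O)N1C(=O)CC(c2ccc(C(=O)OC)cc2)Sc2ccccc21`), which carries methoxycarbonyl in place of methyl on an aromatic carbon, para to a large group: methoxycarbonyl in place of methyl on an aromatic carbon. For the measured compounds named here, one measured step bears directly on this change, since bromo in place of methyl gave a 1.3-fold higher number from compound 1 to compound 2 (0.13 log units; within the scatter) and so stayed within the scatter. Compound 3, with its trifluoromethyl group, gives 96400 nM and falls in the same narrow band. Going by the values given here, no compound with a methoxycarbonyl group has been measured, so this guide is indirect and the range has to stay wide. The expected result is no shift beyond the scatter, with an estimated 1.1-fold higher number from compound 1 to compound 4 (0.05 log units; within the scatter) as the likely size of the step. For compound 4 the estimated value is 105000 nM, with an expected range from 60000 nM to 180000 nM.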

Compound 4, half-maximal inhibitory concentration: 102000 nM
Beside the measured number, compound 4's estimate is 1.0-fold (0.01 log units) above it; measured number inside the range.
By their numbers in this assay, from the lowest: compounds 1, 3, 4 and 2 (each within the scatter of the next).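

In this assay, methoxycarbonyl in place of methyl gives a 1.1-fold higher number from compound 1 to compound 4 (0.03 log units; within the scatter), and methoxycarbonyl in place of bromo gives a 1.2-fold lower number from compound 2 to compound 4 (0.09 log units; within the scatter). The earlier step at this aromatic carbon, para to a large group, only exchanged methyl for bromo, whereas here a group of 4 heavy atoms with 2 hydrogen-bond acceptors enters where methyl had 1 heavy atom and no acceptor, and the number still stays within the scatter. No measured evidence is available to explain why a change of this size leaves the number within the scatter.

The compounds shown leave open whether a free carboxylic acid, an amine or a longer chain at this same place would move the number beyond the scatter, as every group compared here so far has stayed within it. They also leave open whether any change on this ring can shift the result in this cell assay, or whether a change elsewhere in the shared core would be needed to do so.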